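Amide series: 3-fluorophenyl in place of hexyl

A few compounds are considered here, and "the series" means these few. Any claim that something is new, unique, unknown or untested is made for them only; others in the source may bear on it.

Measured so far:
- compound 1, `CCCOc1ccc(C(=O)Nc2cccc(Cl)n2)cc1`: > 100000 nM
- compound 2, `CCCNc1cccc(NC(=O)c2ccc(OCCC)cc2)n1`: 15400 nM
- compound 3, `CCCCCCNc1cccc(NC(=O)c2ccc(OCCC)cc2)n1`: > 100000 nM

In an in vitro assay on HEK-tsA201 cells for antagonist activity at Neuronal acetylcholine receptor; alpha4/beta2 (Homo sapiens), read by fluorescence and calcium flux (on this read-out higher numbers stand for weaker inhibition and lower numbers for stronger inhibition), compound 1 gives > 100000 nM, which is a limit of the assay and not a number. Compound 2 gives 15400 nM. Compound 3 gives > 100000 nM, again a limit rather than a number. For the measured compounds named here, compound 3 thus stands at the unreadable end of the set: two of the three values sit at the same limit (the limit of > 100000 nM in this assay, at which 2 of the 3 values shown sit), and compound 2 is the only one read as a number.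

Compound 4, `CCCOc1ccc(C(=O)Nc2cccc(Nc3cccc(F)c3)n2)cc1`, differs from compound 3 by 3-fluorophenyl in place of hexyl on a nitrogen on an aromatic ring. The measured steps bear on this only loosely. an at least 6.4-fold lower number from compound 1 to compound 2 (0.81 log units; beyond the scatter) shows that a short alkylamino group on that carbon brings the number into the readable range; an at least 6.4-fold higher number from compound 2 to compound 3 (0.81 log units; beyond the scatter) shows that lengthening the chain returns it to the limit; a step that the two limits leave unreadable from compound 1 to compound 3. Going by the values given here, no measured step swaps the chain for an aromatic ring. Since compound 3 starts at a limit, the step of an at least 2.5-fold lower number from compound 3 to compound 4 (0.39 log units; beyond the scatter) is expected to read as lower or not at all. Compound 4 is expected to give around 40000 nM (range 8000 nM to 150000 nM), with a substantial chance that the assay again reports only the limit.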

Compound 4, half-maximal inhibitory concentration: > 100000 nM
Compound 4: no number, only a limit (the forecaster's own chance of this, stated with the estimate: 45%); middle value at least 2.5-fold (0.39 log units) from the limit.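

In this assay compound 4 gives > 100000 nM, which is a limit of the assay and not a number. For the compounds shown here, on the nitrogen on an aromatic ring, an aromatic group now joins the longer chain in giving no readable number, and the change from propyl to 3-fluorophenyl gives an at least 6.4-fold higher number from compound 2 to compound 4 (0.81 log units; beyond the scatter), so propyl remains the only group on that nitrogen with a measured number. The steps to compound 4 from compound 1 and from compound 3 cannot be read, and hexyl and 3-fluorophenyl cannot be ranked against each other, since each of those steps has a limit at both ends: the limit of > 100000 nM in this assay, at which 3 of the 4 values shown sit.

The compounds shown leave open whether a readable number on this nitrogen is confined to short alkyl groups such as ethyl or propyl, or extends to a branched group such as isopropyl or a small ring such as cyclopropyl. They also leave open whether the loss seen with 3-fluorophenyl would hold for unsubstituted phenyl, for 4-fluorophenyl, or for a benzyl group, in which a methylene would separate the ring from the nitrogen.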